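Moving a Methoxy Group Along a Branched Chain

The compounds below may be only part of what the source reports. "The series", "measured", "known", "first", "only" and "open" are said of these compounds alone.

In a functional assay on FaDu cells (Homo sapiens) for cytotoxicity, read by MTT assay, with a stated time of 72 h (on this read-out lower numbers stand for higher toxicity in this test and higher numbers for lower toxicity in this test), compound 1 `COc1ccc(NC(=O)C(=O)c2cn(CC(C)(C)OC)c3ccccc23)cn1` reaches only the limit of > 10000 nM, which is a limit of the test and not a number (the limit of > 10000 nM in this assay, at which 1 of the 3 values shown sits). Two related compounds differ from compound 1 in more than one place: compound 2 `COc1ccc(NC(=O)C(=O)c2cc(C(C)C)n3ccccc23)cn1` gives 160 nM, and compound 3 `COCCn1cc(C(=O)C(=O)Nc2ccc(OC(C)C)nc2)c2ccccc21` gives 55 nM. Compound 4 `COCC(C)(C)n1cc(C(=O)C(=O)Nc2ccc(OC)nc2)c2ccccc21` shares every atom with compound 1, joined differently: 1-(methoxymethyl)-1-methylethyl in place of 2-methoxy-2-methylpropyl on an aromatic nitrogen. For the measured compounds named here, no measured pair shows the effect of such a change, so the expectation rests on compound 1 alone. The step of an at least 1.2-fold lower number from compound 1 to compound 4 (0.09 log units; that floor lies within the scatter) is expected to stay within the usual scatter, with some chance of a modest gain. Compound 4 is thus estimated at 8000 nM, between 1500 nM and 30000 nM.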

Compound 4, concentration lethal to 50% of the cells: 137 nM
Compound 4: middle estimate off by 58-fold (1.77 log units), on the high side; the measured number lies below the stated range.
By their numbers in this assay, from the lowest: compound 3; then compounds 4 and 2 (each within the scatter of the next). At a limit, above all of these: compound 1.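

In this assay, 1-(methoxymethyl)-1-methylethyl in place of 2-methoxy-2-methylpropyl gives an at least 72-fold lower number from compound 1 to compound 4 (1.86 log units; beyond the scatter). On this aromatic nitrogen, then, the way the same atoms are joined can matter a great deal, even with the counted features of the chain unchanged. The size of this step is only a floor, and the value of compound 1 is a limit and not a number: the limit of > 10000 nM in this assay, at which 1 of the 4 values shown sits.

As far as these compounds go, whether the methoxy oxygen matters, or only the branching of the chain, stays open. A tert-butyl group or an amine-bearing chain on the same nitrogen would help to separate the two.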